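The source may report more compounds than this note shows. Statements on the series, on what has been measured and on what is new or still open speak of the compounds shown alone.

Series notes, values in an ADME assay on microsomes from liver (Homo sapiens) for metabolic stability, with a stated time of 10 min; on this read-out higher numbers stand for a more stable compound and lower numbers for a less stable compound:

- compound 1 `COc1cc(C)c(Nc2nc(Cl)cn([C@H](C)C3CC3)c2=O)c(C)n1`: 81%
- compound 2 `Cc1cc(C)c(Nc2nc(Cl)cn([C@H](C)C3CC3)c2=O)c(C)n1`: 76%
- compound 3 `Cc1cc(Nc2nc(Cl)cn([C@H](C)C3CC3)c2=O)c(C)nc1N(C)C`: 29%

Compound 2 at 76% lies within the scatter of compound 1 at 81%, and these two form the upper pair of the three. Compound 3 at 29% lies far lower, well beyond the scatter.

The next step leads to compound 4 `Cc1cc(OC(F)F)nc(C)c1Nc1nc(Cl)cn([C@H](C)C2CC2)c1=O`: difluoromethoxy in place of methyl on an aromatic carbon.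

For the measured compounds named here, one measured step bears on this change: a number 5 percentage points lower from compound 1 to compound 2 (within the scatter), with methyl in place of methoxy on an aromatic carbon. Going by the values given here, that step stays within the scatter, so the one swap between methyl and an oxygen-linked group seen so far left this assay essentially unmoved. Among the compounds with values here, no measured compound carries difluoromethoxy, so this comparison is only indirect. Within the data shown here, no single-place step connects compound 3 to the others, but its value of 29% shows that low numbers occur, and the range is kept wider on the low side.

The expected result is a number 2 percentage points lower from compound 2 to compound 4 (within the scatter), with no shift beyond the scatter anticipated. For compound 4 the estimate is 74%, with an expected range of 55% to 90%.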

Compound 4, percent of the compound remaining: 84%
Compound 4: middle estimate off by 10 percentage points, on the low side; the range from low to high includes it.
By their numbers in this assay, from the lowest: compound 3; then compounds 2, 1 and 4 (each within the scatter of the next).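

Notes on the aromatic carbon next to the ring nitrogen: in this assay the change to difluoromethoxy, with 4 heavy atoms where methyl has 1, gives a number 8 percentage points higher from compound 2 to compound 4 (within the scatter), so a larger group at this place leaves the read-out where methyl had it. The comparison among oxygen-linked groups reads the same way, with difluoromethyl in place of methyl on the oxygen giving a number 3 percentage points higher from compound 1 to compound 4 (within the scatter), and methyl, methoxy and difluoromethoxy on this carbon, in compound 2, compound 1 and compound 4, now form a set with no step beyond the scatter. Nothing available explains why these three groups read alike in this assay.

As far as these compounds go, whether this flat reading holds further at the same carbon stays open, and a longer ether such as ethoxy, a trifluoromethoxy, a nitrile or a carboxylic acid there would test it. From the compounds shown here alone, compound 3 at 29% has no single-place link to this set, so what separates it from the other three also stays open.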